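From compound 2 to compound 3: a sulfonyl exchange

A few compounds are considered here, and "the series" means these few. Any claim that something is new, unique, unknown or untested is made for them only; others in the source may bear on it.

Measured so far in an ADME assay on HEK-293T cells (Homo sapiens) for inhibition, read by CCK-8 assay, with a stated time of 48 h, tested at 20 uM; on this read-out higher numbers stand for more inhibition of growth at the one concentration tested and lower numbers for less inhibition of growth:
Compound 1 `N#C/C(=C\c1ccccc1OS(=O)(=O)c1ccccc1[N+](=O)[O-])C(=O)Nc1nnc(Cc2ccccc2)s1`: 10%
Compound 2 `COc1ccc(S(=O)(=O)Oc2ccccc2/C=C(\C#N)C(=O)Nc2nnc(Cc3ccc(F)cc3)s2)cc1`: 20%

Compound 2 stands at 20% in this series and lies within the usual scatter of compound 1, so the two values are not separated. Compound 3 `N#C/C(=C\c1ccccc1OS(=O)(=O)c1ccccc1[N+](=O)[O-])C(=O)Nc1nnc(Cc2ccc(F)cc2)s1` differs from compound 2 by one exchange: 2-nitrophenyl in place of 4-methoxyphenyl on a sulfonyl sulfur. For the measured compounds named here, no measured pair yet differs in a single place, so the expectation rests only on compound 1 at 10% and compound 2 at 20%. No change beyond the scatter is expected in this assay, and the estimated step is small: a number 5 percentage points lower from compound 2 to compound 3 (within the scatter). For compound 3 the expected value is 15%, with an estimated range from 3% to 30%.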

Compound 3, percent growth inhibition at one concentration: 6%
Beside the measured number, compound 3's estimate is 9 percentage points above it; the measured number falls inside the stated range.
By their numbers in this assay, from the lowest: compounds 3, 1 and 2 (each within the scatter of the next, the first and the last beyond it).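

In this assay the sulfonyl sulfur now has its first single-place comparison: 2-nitrophenyl in place of 4-methoxyphenyl gives a number 14 percentage points lower from compound 2 to compound 3 (beyond the scatter) and so counts as a modest step. With the 2-nitrophenyl kept, fluoro in place of hydrogen on an aromatic carbon gives a number 4 percentage points lower from compound 1 to compound 3 (within the scatter) and is not separated from no change. Nothing measured here accounts for the sulfonyl step. The compounds shown leave open how a plain methyl or a phenyl carrying a carboxylic acid would read on the sulfonyl sulfur.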